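A Phenyl Swap Repeated on a Second Core

The source may hold more compounds than are shown below. What is called first, only, known or untested is meant among the compounds shown, and "the series" means these compounds.

Compound 1, `CC(=O)c1cccn1CCCN1CCN(c2ccc(F)cc2)CC1`, is the starting point. In a functional assay on the whole organism (Abdomen, strain Swiss) for inhibition, with Mus musculus as the target, with stated times of 30 min, 10 min and 5 min, at a dose of 10 mg/kg by the oral route (a higher number here means a stronger effect of the compound at the dose given, a lower number a weaker effect), compound 1 gives 0%. Compound 2, `CC(=O)c1cccn1CCCN1CCN(c2cccc(Cl)c2)CC1`, is its closest relative, and in this assay compound 2 gives 3%. The change between them is 3-chlorophenyl in place of 4-fluorophenyl on an amine nitrogen in a ring, and the step it made is a number 3 percentage points higher from compound 1 to compound 2 (within the scatter).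

Compound 3, `O=c1occ(-c2ccccc2)n1CCCN1CCN(c2ccc(F)cc2)CC1`, carries a different core, and in this assay compound 3 gives 14%. The difference between the core of compound 1 and the core of compound 3 is not broken down here.

Compound 4, `O=c1occ(-c2ccccc2)n1CCCN1CCN(c2cccc(Cl)c2)CC1`, is not yet measured. It differs from compound 3 by 3-chlorophenyl in place of 4-fluorophenyl on an amine nitrogen in a ring, the same change that leads from compound 1 to compound 2, and the surroundings of the place are described in the same words in both cases. Going by the values given here, the step from compound 3 to compound 4 is therefore expected to resemble the earlier one, estimated as a number 3 percentage points higher from compound 3 to compound 4 (within the scatter), because a number 3 percentage points higher from compound 1 to compound 2 (within the scatter) is the only measured instance of this change. For compound 4 the expected read-out in this assay is 17%, estimated to fall between 5% and 30%.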

Compound 4, a percentage reported as inhibition, in the whole organism at one dose (the size of the read-out at that dose, not a potency): 7%
Compound 4: middle estimate off by 10 percentage points, on the high side; the measured number falls inside the stated range.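

On the second core, the swap of 4-fluorophenyl for 3-chlorophenyl gives a number 7 percentage points lower from compound 3 to compound 4 (within the scatter) in this assay, and the comparison with the first core comes out as follows: the same change on two cores in this assay, a number 3 percentage points higher (within the scatter) from compound 1 to compound 2 and a number 7 percentage points lower (within the scatter) from compound 3 to compound 4, 10 percentage points apart, within the scatter of two such steps

So on both cores shown, this change leaves the read-out within the ordinary spread of repeated measurements, and the two cores give no sign of handling it differently. This does not show that the change truly has no effect or has the same effect on both cores, since two small steps at one dose cannot reveal a modest real difference, and they say nothing about potency or about any third core.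

The compounds shown leave open how the read-out responds when a methoxyphenyl or an unsubstituted phenyl sits on the amine nitrogen in the ring. They also leave open what a longer chain would do in place of the chain that carries this six-membered ring.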